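The source may hold more compounds than are shown below. What is called first, only, known or untested is meant among the compounds shown, and "the series" means these compounds.

Compound 1 `CCCCCCCCO[C@@H]1O[C@@H](C)[C@H](OC(=O)CCCCC)[C@@H](O[C@@H]2O[C@@H](C)[C@H](OC(C)=O)[C@@H](O[C@@H]3O[C@@H](C)[C@H](O)[C@@H](O)[C@H]3OC(C)=O)[C@H]2OC(C)=O)[C@H]1O` gives 19.7 ug/mL in a functional assay on Lu1 cells (Homo sapiens) for cytotoxicity; on this read-out higher numbers stand for an effect only at larger amounts of compound and lower numbers for an effect already at smaller amounts. Compound 2 `CCCCCCCCO[C@@H]1O[C@@H](C)[C@H](OC(=O)CCCCC)[C@@H](O[C@@H]2O[C@@H](C)[C@H](OC(C)=O)[C@@H](O)[C@H]2OC(C)=O)[C@H]1O` gives in this assay only a limit, > 20 ug/mL, not a number. Within the data shown here, the two values show compound 1 with a number close to where compound 2 sits at its limit; since the two structures differ in more than one place, no step between them is taken. What is at hand is the limit of > 20 ug/mL in this assay, at which 1 of the 2 values shown sits. Compound 3 `CCCCCCCCO[C@@H]1O[C@@H](C)[C@H](OC(=O)CCCCC)[C@@H](O[C@@H]2O[C@@H](C)[C@H](OC(C)=O)[C@@H](OC(C)=O)[C@H]2OC(C)=O)[C@H]1O` differs from compound 2 by acetyl in place of hydrogen on an oxygen on a saturated carbon. The expected step that the limit leaves unreadable from compound 2 to compound 3 is none beyond the scatter. Compound 3 is estimated at 25 ug/mL, within 12 ug/mL to 60 ug/mL, and a limit rather than a number is again likely.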

Compound 3, concentration for half-maximal effect: 6.1 ug/mL
The estimate for compound 3 lay 4.1-fold (0.61 log units) above the measured number; the whole stated range lies above it.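

In this assay, hydroxy to acetoxy at this place gives an at least 3.2-fold lower number from compound 2 to compound 3 (0.51 log units; beyond the scatter), so a free hydroxy here is not required for the cytotoxic read-out, and acetyl on this oxygen is compatible with a measurable effect. The size of the step is only a minimum, since compound 2 stands at a limit: the limit of > 20 ug/mL in this assay, at which 1 of the 3 values shown sits.

From the compounds shown here alone, whether acetyl is specifically favoured remains open, as a butanoyl ester or a methyl ether on this oxygen would be needed to tell. Also open, going by these compounds, is whether acetyl on the other free hydroxy groups of the shared core acts alike.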